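The compounds below may be only part of what the source reports. "The series", "measured", "known", "first", "only" and "open" are said of these compounds alone.

Three compounds have been measured in an ADME assay on MT4 cells (Homo sapiens) for cytotoxicity, read by MTT assay; on this read-out higher numbers stand for lower toxicity in this test and lower numbers for higher toxicity in this test:

compound 1 `O=C(CSc1nncnc1-c1ccccc1Cl)Nc1ccccc1Br`: 73000 nM
compound 2 `Cc1ccccc1NC(=O)CSc1nncnc1-c1ccccc1Cl`: 142000 nM
compound 3 `O=C(CSc1nncnc1-c1ccccc1Cl)Nc1ccc(Cl)cc1Cl`: 51000 nM

The three numbers lie close together. Compound 3 cannot be told apart from its nearest neighbour, as the measured change shows: a 1.4-fold lower number from compound 1 to compound 3 (0.16 log units; within the scatter). It does separate from the third compound: a 2.8-fold lower number from compound 2 to compound 3 (0.44 log units; beyond the scatter).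

The next compound, compound 4 `O=C(CSc1nncnc1-c1ccccc1Cl)Nc1ccccn1`, carries pyridin-2-yl in place of 2,4-dichlorophenyl on an amide-type nitrogen. Within the data shown here, no measured compound has a ring with a hetero atom at that place, so no step shows this change directly, and any forecast has to lean on the neighbouring steps. Among the measured compounds shown here, the closest guide is compound 2, the only measured compound without halogen on that ring, and its modest step is a 2.8-fold lower number from compound 2 to compound 3 (0.44 log units; beyond the scatter). The remaining step between measured compounds is small: a 1.9-fold higher number from compound 1 to compound 2 (0.29 log units; within the scatter).

A modest move to a higher number in this assay is therefore expected, similar in size to the step involving compound 2, though the basis is thin. The expected change is a 2.5-fold higher number from compound 3 to compound 4 (0.41 log units; beyond the scatter). Compound 4 is estimated at 130000 nM, with an expected range from 60000 nM to 300000 nM.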

Compound 4, half-maximal cytotoxic concentration: 172000 nM
Compound 4: the middle estimate sits 1.3-fold (0.12 log units) below what was measured; low and high end bracket the measured number.
By their numbers in this assay, from the lowest: compounds 3, 1, 2 and 4 (each within the scatter of the next, the first and the last beyond it).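

In this assay, among these compounds, pyridin-2-yl on the amide-type nitrogen is the first ring with a hetero atom at this place, and it separates from both halogen-bearing rings, 2,4-dichlorophenyl (a 3.4-fold higher number from compound 3 to compound 4 (0.53 log units; beyond the scatter)) and 2-bromophenyl (a 2.4-fold higher number from compound 1 to compound 4 (0.37 log units; beyond the scatter)). Against the 2-methylphenyl ring it cannot be told apart (a 1.2-fold higher number from compound 2 to compound 4 (0.08 log units; within the scatter)), so the hetero atom gives no separation from the one carbon-only ring without halogen, and the split between halogen-bearing and halogen-free rings is only partial, since compound 1 also stays within the scatter of compound 2 (a 1.9-fold higher number from compound 1 to compound 2 (0.29 log units; within the scatter)). Nothing measured alongside these numbers speaks to why the values fall as they do.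

From the compounds shown here alone, it remains open whether the ring nitrogen matters at all at this place, which pyridin-3-yl or pyridin-4-yl would test, and whether a pyridin-2-yl ring carrying chlorine would fall with the halogen-bearing rings or stay with compound 4. A saturated ring such as piperidine, or a plain alkyl chain, on the amide-type nitrogen would show whether an aromatic ring is needed there for this read-out at all.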